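The compounds below may be only part of what the source reports. "The series", "measured", "known", "first", "only" and "open" are said of these compounds alone.

Measured in a functional assay on B16-F10 cells (Mus musculus) for antiproliferative activity, read by MTT assay, with a stated time of 72 h; a lower number here means a stronger inhibitor, a higher number a weaker inhibitor:
- compound 1 `CCCCCCCCCCNC[C@@H]1OC[C@H](N)[C@@H]1O`: 29600 nM
- compound 2 `CCCCCCCCNC[C@@H]1OC[C@H](N)[C@@H]1O`: > 128000 nM
- compound 3 `CCCCCCCCCCCCCCNC[C@@H]1OC[C@H](N)[C@H]1O`: 64300 nM

The entry for compound 2 is a limit, not a number. Of the two numeric values, compound 3 has the higher, and compound 1 the lower. Compound 4 `CCCCCCCCCCCCCCNC[C@@H]1OC[C@H](N)[C@@H]1O` departs from compound 3 in one respect: the two compounds have the same atoms and bonds and differ only in configuration as drawn: 1 of 3 stereo elements differ; a stereocentre at a saturated ring carbon is drawn R in compound 3 and S in compound 4. Among the compounds with values here, no measured step changes configuration. The only one, an at least 4.3-fold higher number from compound 1 to compound 2 (0.63 log units; beyond the scatter), alters the chain and bears only indirectly, though both its compounds share the configuration of compound 4. A modest step to a lower number in this assay is therefore expected, with wide uncertainty. The expected change is a 2.1-fold lower number from compound 3 to compound 4 (0.33 log units; beyond the scatter). For compound 4, the estimate is 30000 nM, with an expected range from 8000 nM to 100000 nM.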

Compound 4, half-maximal inhibitory concentration: 14300 nM
Compound 4: the middle estimate sits 2.1-fold (0.32 log units) above what was measured, within the range that was stated.
By their numbers in this assay, from the lowest: compound 4; then compound 1; then compound 3. At a limit, above all of these: compound 2.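

In this assay, within the data shown here, a 4.5-fold lower number from compound 3 to compound 4 (0.65 log units; beyond the scatter) is the first measured change of configuration alone, showing that the S drawing at this saturated ring carbon gives the lower number with the chain held fixed: the fact that compounds 3 and 4 differ only in the configuration as drawn. With that configuration, butyl in place of hydrogen gives a 2.1-fold lower number from compound 1 to compound 4 (0.32 log units; beyond the scatter). Hexyl in place of hydrogen gives an at least 8.9-fold lower number from compound 2 to compound 4 (0.95 log units; beyond the scatter), a step that rests on a limit, not a number.

From the compounds shown here alone, whether the same configuration gives the lower number with a shorter chain remains open. So does what a longer chain, or an acetamide in place of the free amine, would do.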